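The compounds below may be only part of what the source reports. "The series", "measured", "known", "first", "only" and "open" are said of these compounds alone.

Measured compounds:

Compound 1, `C=C(Br)C(=O)Nc1ccc(C(=O)/C=C/c2ccccc2OC)cc1`: 240 nM
Compound 2, `C=C(Br)C(=O)Nc1ccc(C(=O)/C=C/c2cccc(OC)c2OC)cc1`: 490 nM
Compound 3, `COc1cccc(/C=C/C(=O)c2ccc(N)cc2)c1`: 21000 nM

All three were run in a functional assay on MOLT-4 cells (Homo sapiens) for antiproliferative activity, with a stated time of 48 h; on this read-out higher numbers stand for weaker inhibition and lower numbers for stronger inhibition. Compound 1 and compound 2 share one core; the step of a 2.0-fold higher number from compound 1 to compound 2 (0.31 log units; beyond the scatter) describes the change (methoxy in place of hydrogen on an aromatic carbon). Compound 3 carries a different core, and the difference between the two cores is not broken down here. Its value in this assay, 21000 nM for compound 3, stands well apart from the numbers of compound 1 and compound 2, both of which are much lower.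

Compound 4, `COc1cc(/C=C/C(=O)c2ccc(N)cc2)cc(OC)c1`, has not yet been measured in this assay. It is made from compound 3 by methoxy in place of hydrogen on an aromatic carbon. Within the data shown here, this is the same kind of change as that from compound 1 to compound 2, but not the same: in compound 2 the entering methoxy sits ortho to a methoxy group and meta to a large group, whereas in compound 4 it sits meta to a large group and meta to a methoxy group, and the core it is placed on is the one of compound 3, not of compound 1.

Among the measured compounds shown here, with only one measured instance of this change, on another core and in another surrounding, the expectation for compound 4 rests on the step of a 2.0-fold higher number from compound 1 to compound 2 (0.31 log units; beyond the scatter) and on the starting point set by compound 3, which gives 21000 nM. The step from compound 3 to compound 4 is expected to be modest, a 1.7-fold higher number from compound 3 to compound 4 (0.22 log units; within the scatter), in the same direction as the earlier one. Compound 4 is therefore estimated at 35000 nM in this assay, with a range from 12000 nM to 100000 nM to allow for the change of core.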

Compound 4, half-maximal inhibitory concentration: 7500 nM
Estimate against measurement, compound 4: 4.7-fold (0.67 log units) above; the measured number lies below the stated range.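

In this assay, the new step is a 2.8-fold lower number from compound 3 to compound 4 (0.45 log units; beyond the scatter), opposite in direction to the earlier step, a 2.0-fold higher number from compound 1 to compound 2 (0.31 log units; beyond the scatter). Within this series, a methoxy in place of hydrogen on an aromatic carbon therefore does not carry its direction or size from one core to the other: the same change on two cores in this assay, a 2.0-fold higher number (0.31 log units; beyond the scatter) from compound 1 to compound 2 and a 2.8-fold lower number (0.45 log units; beyond the scatter) from compound 3 to compound 4, 5.7-fold (0.76 log units) apart, beyond the scatter of two such steps

This does not show that the core alone sets the outcome, as the entering methoxy also stands differently relative to the existing methoxy in compound 2 and compound 4, and two steps cannot separate the core from the place of substitution.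

As far as these compounds go, it remains open whether a hydroxy group or an ethoxy chain at the same place on the core of compound 3 would follow the methoxy step, and what a methoxy at that same place on the core of compound 1 would give. The gap between the two cores also stays unresolved, as the compounds on one core differ from those on the other in more than one place.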